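From Amino to Oxy Link on Compound 2

The source may hold more compounds than are shown below. What is called first, only, known or untested is meant among the compounds shown, and "the series" means these compounds.

In a physicochemical assay for solubility, in phosphate buffer (on this read-out lower numbers stand for lower solubility and higher numbers for higher solubility), compound 2 (`C#CC(=O)Nc1ccc(CCCCCC)cc1`) gives 60000 nM and compound 1 (`C/C=C/C(=O)Nc1ccc(CCCCCC)cc1`) gives 42000 nM in the same read-out, so the two lie within the scatter of each other. Compound 3 (`C#CC(=O)Oc1ccc(CCCCCC)cc1`), still unmeasured, departs from compound 2 at one place on an aromatic carbon ((ethynylcarbonyl)oxy in place of (ethynylcarbonyl)amino on an aromatic carbon) while the shared core stays as it is. For the measured compounds named here, the only measured step (a 1.4-fold higher number from compound 1 to compound 2 (0.15 log units; within the scatter)) lies within the scatter, yet it changes the group on the carbonyl carbon and not the link to the aromatic carbon, so it offers only a rough guide to size and none to direction. Nothing measured here tests this exchange, and no step beyond the scatter is expected in this assay for it. The expected step is a 1.2-fold lower number from compound 2 to compound 3 (0.08 log units; within the scatter) as a rough estimate. For compound 3 the estimate is 50000 nM with an expected range from 20000 nM to 100000 nM in this read-out.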

Compound 3, solubility: 18000 nM
Compound 3: middle estimate off by 2.8-fold (0.44 log units), on the high side; the measured number lies below the stated range.
By their numbers in this assay, from the lowest: compound 3; then compounds 1 and 2 (each within the scatter of the next).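

In this assay the link to the aromatic carbon proves to count where the earlier change on the carbonyl carbon stayed within the scatter: (ethynylcarbonyl)oxy in place of (ethynylcarbonyl)amino gives a 3.3-fold lower number from compound 2 to compound 3 (0.52 log units; beyond the scatter) on an otherwise unchanged compound. Set against the other amide, with ((prop-1-en-1-yl)carbonyl)amino leaving, the change gives a 2.3-fold lower number from compound 1 to compound 3 (0.37 log units; beyond the scatter) and so compound 3 stands lowest of the three, beyond the scatter of both others. Nothing available here accounts for this fall in the number.

The compounds shown leave open how a sulfur link or a methylamino link on the same aromatic carbon would stand on this read-out. They also leave open whether the oxy link with prop-1-en-1-yl on the carbonyl carbon would give a step of like size.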